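Changing the aryl on the piperazine of compound 1

The compounds below may be only part of what the source reports. "The series", "measured", "known", "first", "only" and "open" are said of these compounds alone.

Compound 1 `Cc1ccc(C)c(N2CCN(C(=O)c3oc(C)nc3-c3ccccc3)CC2)c1` gives 31.3 nM in a functional assay on HL-60 cells (Homo sapiens) for inhibition, read by MTT assay, with a stated time of 72 h (a higher number here means a weaker inhibitor, a lower number a stronger inhibitor), the lower of the two numbers measured here. Compound 2 `Cc1ccc(C)c(N2CCN(C(=O)c3oc(C)nc3-c3ccccc3F)CC2)c1` gives 319 nM, and the step of a 10-fold higher number from compound 1 to compound 2 (1.01 log units; beyond the scatter) lies on the phenyl attached to the shared core, not on the piperazine aryl. Compound 3 `Cc1nc(-c2ccccc2)c(C(=O)N2CCN(c3ccc(Cl)c(Cl)c3)CC2)o1` differs from compound 1 by 3,4-dichlorophenyl in place of 2,5-dimethylphenyl on an amine nitrogen in a ring. Among the compounds with values here, no measured step touches this position, so the data give no direction for the change, and the uncertainty is wide. Compound 3 is estimated to give 100 nM (range 15 nM to 700 nM), an expected step of a 3.2-fold higher number from compound 1 to compound 3 (0.50 log units; beyond the scatter).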

Compound 3, half-maximal inhibitory concentration: 124 nM
Compound 3: the middle estimate sits 1.2-fold (0.09 log units) below what was measured; the measured number falls inside the stated range.
By their numbers in this assay, from the lowest: compound 1; then compound 3; then compound 2.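

The position on the amine nitrogen in a ring is not indifferent to the aryl group it carries: in this assay there is a 4.0-fold higher number from compound 1 to compound 3 (0.60 log units; beyond the scatter) with 3,4-dichlorophenyl in place of 2,5-dimethylphenyl. Of the two aryl groups seen at this position, 2,5-dimethylphenyl gives the lower number. Nothing available here explains this step.

This single swap replaces the substituents and their places together, so the part each plays remains unresolved. As far as these compounds go, how a methoxy group or an amine on this aryl ring would read also remains open.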